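The compounds below may be only part of what the source reports. "The series", "measured", "known", "first", "only" and "open" are said of these compounds alone.

Working notes on the series, read in a functional assay on MCF7 cells (Homo sapiens) for antiproliferative activity, read by MTT assay, with a stated time of 48 h; on this read-out lower numbers stand for stronger inhibition and higher numbers for weaker inhibition. For the measured compounds named here, compound 2 (`COc1ccc(-c2c(Nc3ccc(C)c(O)c3)c3ccccc3oc2=O)cc1`) gives 12100 nM, the lowest of the three numbers so far. Compound 3 (`COc1ccc(-c2c(Nc3ccc(C)cc3)c3ccccc3oc2=O)cc1`) gives 65300 nM, and compound 1 (`COc1ccc(-c2c(Nc3cc(OC)c(OC)c(OC)c3)c3ccccc3oc2=O)cc1`) gives 82300 nM; each of these lies beyond the scatter from the value of compound 2.

The next structure is compound 4 (`COc1ccc(-c2c(Nc3ccc(NC(C)=O)cc3)c3ccccc3oc2=O)cc1`), and the change is 4-acetamidophenyl in place of 3-hydroxy-4-methylphenyl on a nitrogen on an aromatic ring. Going by the values given here, the hydroxy group of compound 2 leaves with the 3-hydroxy-4-methylphenyl, so the one measured step that bears on this change is a 5.4-fold higher number from compound 2 to compound 3 (0.73 log units; beyond the scatter), where hydrogen takes the place of hydroxy on an aromatic carbon. That step is modest but beyond the scatter. Among the compounds with values here, compound 1, which also has no hydroxy group, gives 82300 nM, and no compound without one goes against the trend so far, though three compounds make a thin basis. Within the data shown here, no measured compound carries the 4-acetamidophenyl, so its own contribution is unknown and the range stays wide.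

A modest rise is therefore expected, of about the size seen on removing the hydroxy group or somewhat less. The expected step is a 2.9-fold higher number from compound 2 to compound 4 (0.46 log units; beyond the scatter), toward a higher number. Compound 4 is estimated at 35000 nM, with an expected range of 12000 nM to 90000 nM.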

Compound 4, half-maximal inhibitory concentration: > 100000 nM
Compound 4 ended at the assay's limit (the forecaster's own chance of this, stated with the estimate: 5%); middle value at least 2.8-fold (0.45 log units) from the limit.
By their numbers in this assay, from the lowest: compound 2; then compounds 3 and 1 (each within the scatter of the next). At a limit, above all of these: compound 4.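

In this assay compound 4 reads > 100000 nM, which is a limit of the assay and not a number: the limit of > 100000 nM in this assay, at which 1 of the 4 values shown sits. Placing 4-acetamidophenyl on the nitrogen in place of 3-hydroxy-4-methylphenyl gives an at least 8.2-fold higher number from compound 2 to compound 4 (0.91 log units; beyond the scatter), so this change on the nitrogen costs at least as much as the loss of the hydroxy group alone, a 5.4-fold higher number from compound 2 to compound 3 (0.73 log units; beyond the scatter), and the acetamido group does not make up for that loss. Acetamido in place of methyl gives an at least 1.5-fold higher number from compound 3 to compound 4 (0.18 log units; that floor lies within the scatter), so compound 4 cannot be ordered against compound 3, and the loss relative to compound 2 cannot be divided between the departing hydroxy group and the entering acetamido group.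

As far as these compounds go, it remains open whether a hydroxy group added to the 4-acetamidophenyl would bring the number back toward that of compound 2. Also open, from the compounds shown here alone, is what an amine or a carboxylic acid would give in place of the acetamido group on the same ring, and whether any such group would give a reading within the range of this assay.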